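From phenyl to cyclopentyloxy in growth inhibition

The source may report more compounds than this note shows. Statements on the series, on what has been measured and on what is new or still open speak of the compounds shown alone.

In a functional assay on M21 cells (Homo sapiens) for inhibition, read by sulforhodamine B assay, with a stated time of 48 h (a lower number here means a stronger inhibitor of growth, a higher number a weaker inhibitor of growth), compound 2 (`O=C(CCl)NC(=O)Nc1ccc(-c2ccccc2)cc1`) gives 1400 nM and compound 1 (`O=C(CCl)NC(=O)Nc1ccc(C2CCCCC2)cc1`) gives 900 nM within the scatter of each other, so compound 2 does not stand apart on the two numbers available. Compound 3 (`O=C(CCl)NC(=O)Nc1ccc(OC2CCCC2)cc1`) carries cyclopentyloxy in place of phenyl on an aromatic carbon. Among the measured compounds shown here, the only measured step bearing on this is a 1.6-fold higher number from compound 1 to compound 2 (0.19 log units; within the scatter) for phenyl in place of cyclohexyl on an aromatic carbon, so no step beyond the scatter is expected in this assay here. The estimate means a 1.2-fold lower number from compound 2 to compound 3 (0.07 log units; within the scatter) as the expected step. For compound 3 the expected value is 1200 nM (500 nM to 3000 nM).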

Compound 3, concentration for 50% growth inhibition: 2900 nM
Compound 3: the middle estimate sits 2.4-fold (0.38 log units) below what was measured; the measured number falls inside the stated range.
By their numbers in this assay, from the lowest: compounds 1 and 2 (each within the scatter of the next); then compound 3.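

Until now, changing the group at this position had produced no step beyond the scatter in this assay. Cyclopentyloxy changes that, with a 2.1-fold higher number from compound 2 to compound 3 (0.32 log units; beyond the scatter) and a 3.2-fold higher number from compound 1 to compound 3 (0.51 log units; beyond the scatter), making compound 3 the weakest inhibitor of growth of the three, although both steps are modest. No available evidence accounts for this loss.

The compounds shown leave open whether the loss follows the oxygen link or the five-membered ring, which cyclopentyl and cyclohexyloxy at this position could separate. On these data alone, how an amine or a carboxylic acid would fare here also remains open.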